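The source may report more compounds than this note shows. Statements on the series, on what has been measured and on what is new or still open speak of the compounds shown alone.

In an ADME assay on MT4 cells (Homo sapiens) for cytotoxicity, read by MTT assay, with a stated time of 96 h (a lower number here means that less compound is tolerated, a higher number that more compound is tolerated), compound 3 `CC(=O)Oc1ccc2c(C)cc(=O)oc2c1Cc1c(-c2ccccc2)[nH]c2ccccc12` stands at > 100000 nM, which is a limit of the assay and not a number. The next structure, compound 4 `CC(=O)Oc1ccc2c(C)cc(=O)oc2c1Cc1c[nH]c2ccccc12`, has hydrogen in place of phenyl on an aromatic carbon. For the measured compounds named here, no measured step makes this change. Going by the values given here, compound 1 `CCC(=O)Oc1ccc2c(C)cc(=O)oc2c1Cc1c(-c2ccccc2)[nH]c2ccccc12` gives 38000 nM, but the one measured step, an at least 2.6-fold higher number from compound 1 to compound 3 (0.42 log units; beyond the scatter), leaves the phenyl untouched and so bears on the change only indirectly. The nearest guide is compound 2 `COc1ccc2[nH]cc(Cc3c(OC(C)=O)ccc4c(C)cc(=O)oc34)c2c1`, which has no phenyl but differs elsewhere too, and it gives 72000 nM. A modest move toward a lower number in this assay is therefore expected, an estimated at least 1.4-fold lower number from compound 3 to compound 4 (0.15 log units; that floor lies within the scatter). For compound 4 the expected value is 70000 nM, within an estimated range of 30000 nM to 100000 nM.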

Compound 4, half-maximal cytotoxic concentration: 100000 nM
Estimate against measurement, compound 4: 1.4-fold (0.15 log units) below; measured number inside the range.
By their numbers in this assay, from the lowest: compounds 1, 2 and 4 (each within the scatter of the next, the first and the last beyond it).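

In this assay, compound 4, which carries hydrogen in place of phenyl, gives a measured number, 100000 nM, so this change leaves a value that can be compared. Compound 3 has only a limit of the assay and not a number: the limit of > 100000 nM in this assay, at which 1 of the 4 values shown sits. The data show a number no higher from compound 3 to compound 4 (the limit leaves the size open) and the size of this step cannot be read, while a 1.4-fold higher number from compound 2 to compound 4 (0.14 log units; within the scatter) shows that the loss of the methoxy stays within the scatter. On these data alone, whether a methyl or an amine on the aromatic carbon next to the ring nitrogen would shift the number from that of compound 4 remains open.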